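The source may report more compounds than this note shows. Statements on the series, on what has been measured and on what is new or still open speak of the compounds shown alone.

The measured compounds:
Compound 1, `Oc1nc2ncc(-c3ccccc3)nc2n1Cc1ccc2ncccc2c1`, gives > 10000 nM in a functional assay on NCI-H1993 cells (Homo sapiens) for inhibition, read by CCK-8 assay, with a stated time of 72 h (on this read-out higher numbers stand for weaker inhibition and lower numbers for stronger inhibition), which is a limit of the assay and not a number.
Compound 2, `Oc1nc2ncc(-c3ccncc3)nc2n1Cc1ccc2ncccc2c1`, gives > 10000 nM in this assay, again only a limit.
Compound 3, `CC(c1cc(F)c2ncccc2c1)n1cnc2ncc(-c3ccncc3)nc21`, gives > 10000 nM in this assay, likewise a limit.

For the measured compounds named here, every value so far rests at the limit of > 10000 nM in this assay, at which 3 of the 3 values shown sit. Compound 1 differs from compound 2 by phenyl in place of pyridin-4-yl on an aromatic carbon, and the step that the two limits leave unreadable from compound 2 to compound 1. The difference between the cores of compound 2 and compound 3 is not broken down here. Compound 4, `CC(c1cc(F)c2ncccc2c1)n1cnc2ncc(-c3ccccc3)nc21`, differs from compound 3 by phenyl in place of pyridin-4-yl on an aromatic carbon, the same change in the same place.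

Compound 4 is expected to give 20000 nM in this assay, with an expected range from 8000 nM to 60000 nM, and most probably only a limit will be reported. The expected step that the limit leaves unreadable from compound 3 to compound 4 rests on compound 3 showing > 10000 nM and on the same change having stayed unreadable in a step that the two limits leave unreadable from compound 2 to compound 1.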

Compound 4, half-maximal inhibitory concentration: > 10000 nM
Compound 4: only a limit was reported; the forecaster's own chance of this, stated with the estimate: 85%; the middle value lies beyond the limit too.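

Compound 3 and compound 4 both stop at a limit and not at a number, so no step can be read between them: the limit of > 10000 nM in this assay, at which 4 of the 4 values shown sit. The compounds shown leave open whether phenyl and pyridin-4-yl differ at all in this assay.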